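The source may report more compounds than this note shows. Statements on the series, on what has been measured and on what is new or still open speak of the compounds shown alone.

Measured so far:
- compound 1 `CN(C(=O)NC(=O)c1ccc(Cl)cc1Cl)c1nc(C(F)(F)F)c(C(=O)N/N=C/c2cccc(C(F)(F)F)c2)s1`: 10.7 ug/mL
- compound 2 `CN(C(=O)NC(=O)c1ccc(F)c(F)c1)c1nc(C(F)(F)F)c(C(=O)N/N=C/c2cc(C(F)(F)F)cc(C(F)(F)F)c2)s1`: 2.61 ug/mL

In a functional assay on MCF7 cells (Homo sapiens) for inhibition, read by MTT assay, with a stated time of 72 h (a higher number here means a weaker inhibitor, a lower number a stronger inhibitor), compound 2 gives 2.61 ug/mL, the lower of the two numbers recorded, and compound 1 gives 10.7 ug/mL, a gap that lies beyond the scatter. Among the compounds with values here, no single-point step connects these two, since they differ in two places at once, so the two values are taken only as they stand.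

Compound 3 `CN(C(=O)NC(=O)c1ccc(Cl)cc1Cl)c1nc(C(F)(F)F)c(C(=O)N/N=C/c2cc(C(F)(F)F)cc(C(F)(F)F)c2)s1` is the next candidate. The change from compound 2 is 2,4-dichlorophenyl in place of 3,4-difluorophenyl on a carbonyl carbon. The hydrazone part of compound 3 matches compound 2; its acyl part matches compound 1. A modest upward move in this assay is expected for compound 3, on the order of a 1.7-fold higher number from compound 2 to compound 3 (0.24 log units; within the scatter). The estimate for compound 3 in this assay is 4.5 ug/mL, with a range from 1.8 ug/mL to 11 ug/mL; the wide range reflects the two-point basis.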

Compound 3, half-maximal inhibitory concentration: > 100 ug/mL
Compound 3: a limit, no number; the forecaster's own chance of this, stated with the estimate: 5%; middle value at least 22-fold (1.34 log units) from the limit.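

Compound 3 sits at a limit of this assay and has no number: the limit of > 100 ug/mL in this assay, at which 1 of the 3 values shown sits.

Within the data shown here, with the hydrazone part held fixed, 2,4-dichlorophenyl in place of 3,4-difluorophenyl on a carbonyl carbon whose other neighbour is amide-type nitrogen gives an at least 38-fold higher number from compound 2 to compound 3 (1.58 log units; beyond the scatter), so this place carries a large effect that the two-place difference between the earlier compounds could not isolate. With the 2,4-dichlorophenyl acyl part held fixed, trifluoromethyl in place of hydrogen on an aromatic carbon gives an at least 9.3-fold higher number from compound 1 to compound 3 (0.97 log units; beyond the scatter), so this second change also goes with a loss in this pair.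

Left open is whether the loss follows the halogen or its placement on the ring, which 2,4-difluorophenyl or 3,4-dichlorophenyl at the same carbonyl would separate. Also open, on these data alone, are the effect of the same trifluoromethyl change with the 3,4-difluorophenyl acyl part and the reading for an unsubstituted phenyl or a methoxyphenyl at this place.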